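The compounds below may be only part of what the source reports. "The series", "measured", "known", "first", "only" and "open" are said of these compounds alone.

The series rests on a shared core, varied at two ends. Compound 1 `CC(O)(COc1ccc(C#N)cc1)C(=O)Nc1ccc(S(F)(F)(F)(F)F)cc1` and compound 2 `CC(O)(COc1ccc(C#N)cc1C(F)(F)F)C(=O)Nc1ccc(S(F)(F)(F)(F)F)cc1` carry a nitrile-bearing ring joined through an ether; compound 3 `CC(O)(CS(=O)(=O)c1cccc(C(F)(F)F)c1)C(=O)Nc1ccc(S(F)(F)(F)(F)F)cc1` and the not yet measured compound 4 `CC(O)(CS(=O)(=O)c1cc(C(F)(F)F)cc(C(F)(F)F)c1)C(=O)Nc1ccc(S(F)(F)(F)(F)F)cc1` carry instead a ring joined through a sulfone. How the core of compound 1 and the core of compound 3 differ is not broken down here.

In a functional assay on VCaP cells (Homo sapiens) for antiproliferative activity, read by propidium iodide staining, with a stated time of 96 h (a higher number here means a weaker inhibitor, a lower number a stronger inhibitor), compound 1 gives 100000 nM. Compound 2 differs from compound 1 by trifluoromethyl in place of hydrogen on an aromatic carbon. In this assay compound 2 gives 100000 nM, so that the step of no change at the digits printed from compound 1 to compound 2 (within the scatter). Compound 3 gives 32000 nM in this assay, the lowest of the three numbers seen so far, and its gap to compound 1 and to compound 2 lies beyond the scatter.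

Compound 4 differs from compound 3 by trifluoromethyl in place of hydrogen on an aromatic carbon. This is the same kind of change as that from compound 1 to compound 2, but not the same: there the entering group sat ortho to a large group and meta to a cyano group, here it sits meta to a large group and meta to a trifluoromethyl group. Because the earlier step of no change at the digits printed from compound 1 to compound 2 (within the scatter), the step from compound 3 to compound 4 is expected to be small as well, about a 1.1-fold lower number from compound 3 to compound 4 (0.03 log units; within the scatter). Compound 4 is therefore estimated at 30000 nM in this assay, within a range from 10000 nM to 100000 nM.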

Compound 4, half-maximal inhibitory concentration: 15800 nM
Compound 4: middle estimate off by 1.9-fold (0.28 log units), on the high side; the measured number falls inside the stated range.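

On the core carrying the sulfone, trifluoromethyl in place of hydrogen on an aromatic carbon gives a 2.0-fold lower number from compound 3 to compound 4 (0.31 log units; beyond the scatter) in this assay, whereas the same change on the core carrying the ether gives no change at the digits printed from compound 1 to compound 2 (within the scatter). Read on their own, the two steps look different, but set side by side they cannot be told apart: the same change on two cores in this assay, no change at the digits printed (within the scatter) from compound 1 to compound 2 and a 2.0-fold lower number (0.31 log units; beyond the scatter) from compound 3 to compound 4, 2.0-fold (0.31 log units) apart, within the scatter of two such steps. For the compounds shown here, the change can therefore be carried from one core to the other without a measurable difference in its effect, yet this does not show that the effect is the same on both cores, since it rests on only two pairs of compounds, and the entering group has different neighbours on the ring in each pair.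

The compounds shown leave open how other groups at the same place on the ring, such as an amine, a carboxylic acid or a chlorine atom, would compare with trifluoromethyl and whether any such step would carry between these two cores. They also leave open how the ether and the sulfone compare when joined to an identically substituted ring, and what replacing the hydroxyl group on the shared core with an amine would do in this assay.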